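This account rests on a few compounds, and the source may have more. Where it says the series, first, only, none or still open, it means among the compounds named here.

For the measured compounds named here, compound 1 `COc1cc2nc(N3CCN(S(=O)(=O)c4ccc(OC(F)(F)F)cc4)CC3)nc(N)c2cc1OC` stands at the top of the two numbers measured in a functional assay on PC-3 cells (Homo sapiens) for inhibition (on this read-out higher numbers stand for weaker inhibition and lower numbers for stronger inhibition), with 25000 nM, though its only neighbour is close: compound 2 `COc1cc2nc(N3CCN(S(=O)(=O)c4cccc5ccccc45)CC3)nc(N)c2cc1OC` gives 14000 nM in this assay, and the step from a 1.8-fold lower number from compound 1 to compound 2 (0.25 log units; within the scatter), naphthalen-1-yl in place of 4-(trifluoromethoxy)phenyl on a sulfonyl sulfur, stays inside the scatter. Compound 3 `COc1cc2nc(N3CCN(S(=O)(=O)c4ccc(-c5ccc(C(C)(C)C)cc5)cc4)CC3)nc(N)c2cc1OC` has not yet been measured in this assay. It differs from compound 1 by 4-(tert-butyl)phenyl in place of trifluoromethoxy on an aromatic carbon. Going by the values given here, the one measured step, a 1.8-fold lower number from compound 1 to compound 2 (0.25 log units; within the scatter), is the only guide: it also replaces the aryl group on the sulfonyl sulfur with a larger hydrocarbon ring system, and it moved the number by less than the scatter. On that basis, and with both measured numbers lying in the weak range, compound 3 is expected to stay near compound 1, with a step of a 1.3-fold lower number from compound 1 to compound 3 (0.10 log units; within the scatter) expected in this assay rather than anything beyond the scatter. Compound 3 is therefore estimated at 20000 nM in this assay, with a range from 6000 nM to 60000 nM.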

Compound 3, half-maximal inhibitory concentration: 10000 nM
Estimate against measurement, compound 3: 2.0-fold (0.30 log units) above, and the stated range covers the measured number.
By their numbers in this assay, from the lowest: compounds 3, 2 and 1 (each within the scatter of the next, the first and the last beyond it).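

In this assay, for the compounds shown here, putting 4-(tert-butyl)phenyl in place of trifluoromethoxy on an aromatic carbon, para to a large group, gives a 2.5-fold lower number from compound 1 to compound 3 (0.40 log units; beyond the scatter), the first step here to lie beyond the scatter. The entering group has 10 heavy atoms and one six-membered aromatic ring, against 5 heavy atoms and no ring in the group that leaves, so this place accepts a much larger group while the number goes down rather than up, although the step is only modest and compound 3 still gives 10000 nM. No measured evidence is available to account for this step.

The compounds shown leave open how a plain phenyl would read at this place, so the contributions of the added ring and of its tert-butyl end cannot be told apart. As far as these compounds go, it also remains open whether an amine or a carboxylic acid in place of that tert-butyl would keep the number at this level or move it in either direction.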